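The source may hold more compounds than are shown below. What is called first, only, known or untested is meant among the compounds shown, and "the series" means these compounds.

From a functional assay on A549 cells (Homo sapiens) for inhibition, read by sulforhodamine B assay, with a stated time of 48 h, tested at 50 uM (a lower number here means less inhibition of growth, a higher number more inhibition of growth at the concentration tested), the values are:
- compound 1 `COc1ccc([C@@H]2C/C(=N/O)c3cc(CC=C(C)C)c(OC)cc3O2)cc1` gives 66%
- compound 2 `COc1cc2c(cc1CC=C(C)C)/C(=N/NC(N)=O)C[C@@H](c1ccc(O)cc1)O2` gives 77%
- compound 3 `COc1ccc([C@@H]2C/C(=N/OCc3cn(-c4ccccc4CO)nn3)c3cc(CC=C(C)C)c(OC)cc3O2)cc1` gives 100%

Compound 2 stands second of the three, above compound 1 and below compound 3, with both gaps beyond the scatter. Compound 4 `COc1cc2c(cc1CC=C(C)C)/C(=N/O)C[C@@H](c1ccc(O)cc1)O2` has hydroxy in place of ureido on a double-bonded nitrogen relative to compound 2. Among the measured compounds shown here, no step between measured compounds is available to size this change. Compound 1, also with hydroxy on a double-bonded nitrogen, gives 66% and so points to a small fall in this assay, close to the scatter. The expected change is a number 9 percentage points lower from compound 2 to compound 4 (within the scatter) as an estimate. For compound 4 the estimated value is 68% (expected range 52% to 84%).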

Compound 4, percent growth inhibition at one concentration: 80%
Beside the measured number, compound 4's estimate is 12 percentage points below it; the range from low to high includes it.
By their numbers in this assay, from the lowest: compound 1; then compounds 2 and 4 (each within the scatter of the next); then compound 3.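

In this assay, hydroxy in place of ureido on a double-bonded nitrogen gives a number 3 percentage points higher from compound 2 to compound 4 (within the scatter), the first step read at this position. On this core, the number therefore holds with one heavy atom at this position in place of four, so the full ureido is not required to keep growth inhibition at the concentration tested. No supporting data bear on the reason for this result.

From the compounds shown here alone, whether an amine or a longer carbon chain at this position would give a similar number remains open. A single step on one core also leaves open whether the same swap behaves alike on other cores.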